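A few compounds are considered here, and "the series" means these few. Any claim that something is new, unique, unknown or untested is made for them only; others in the source may bear on it.

Measured compounds:
- Compound 1 `Cc1cc(NC(=O)Cn2nnc(-c3ccccc3)n2)n(C2CCC(F)(F)CC2)n1` — in an assay on HEK293 cells for activation of Kir3.1/Kir3.2 (Homo sapiens), read by thallium flux (a lower number here means that less compound is needed, a higher number that more compound is needed for the effect), compound 1 gives 84 nM
- Compound 2 `CC1CC1c1cc(NC(=O)Cn2nnc(-c3ccccc3)n2)n(C2CCCCC2)n1` — in this assay compound 2 gives 843 nM
- Compound 3 `Cc1cc(NC(=O)Cn2nnc(-c3cccc(Cl)c3)n2)n(C2CCCCC2)n1` — in this assay compound 3 gives 300 nM

Of the three numbers shown, compound 3 holds the second highest. The nearest to it is compound 2, whose number in this assay is higher than that of compound 3 by a margin beyond the usual scatter. The furthest is compound 1, whose number is lower than that of compound 3, again beyond the scatter. Among the compounds with values here, compound 1 also differs from compound 3 in more than one place, so these two values are only set side by side here and no single step is read from them.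

The next compound, compound 4 `Cc1cc(NC(=O)Cn2nnc(-c3cccc(F)n3)n2)n(C2CCCCC2)n1`, differs from compound 3 in one place: 6-fluoropyridin-2-yl in place of 3-chlorophenyl on an aromatic carbon. Within the data shown here, no step between measured compounds resembles this change, so there is no direct yardstick for its size. The expectation is a modest move toward a higher number in this assay, possibly within the scatter, giving an estimated step from compound 3 to compound 4 of a 1.5-fold higher number from compound 3 to compound 4 (0.18 log units; within the scatter). Compound 4 is therefore expected to give about 450 nM, with a likely range from 150 nM to 1500 nM.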

Compound 4, half-maximal effective concentration: > 3000 nM
Compound 4 was reported as a limit; the forecaster's own chance of this, stated with the estimate: 5%; middle value at least 6.6-fold (0.82 log units) away from the limit.
By their numbers in this assay, from the lowest: compound 1; then compound 3; then compound 2. At a limit, above all of these: compound 4.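

In this assay compound 4 gives > 3000 nM, which is a limit of the assay and not a number. Placing 6-fluoropyridin-2-yl in place of 3-chlorophenyl on the aromatic carbon of the five-membered aromatic ring with 4 nitrogen gives an at least 10-fold higher number from compound 3 to compound 4 (1.00 log units; beyond the scatter), the first step in the set that can be read at a single place, and it shows that this position does not treat these two six-membered aromatic rings alike, although each group holds 7 heavy atoms. The size of this step is only a bound and not a measured difference: the limit of > 3000 nM in this assay, at which 1 of the 4 values shown sits.

The change alters the ring and the halogen at once, bringing in a ring nitrogen and a hydrogen-bond acceptor while fluorine replaces chlorine, and the compounds shown do not tell which of these accounts for the step. On these data alone, a fluorophenyl group or a chloropyridinyl group at this position would separate the two, and how far the number in this assay truly moves also remains open.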